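The source may hold more compounds than are shown below. What is called first, only, known or untested is meant among the compounds shown, and "the series" means these compounds.

Series notes. Compound 1 `COc1ccc2c(c1)c(C=O)cn2Cc1cn([C@@H]2O[C@H](COC(C)=O)[C@@H](OC(C)=O)[C@H](OC(C)=O)[C@H]2OC(C)=O)nn1` carries a formyl group on the shared core. In an ADME assay on NIH3T3 cells (Homo sapiens) for cytotoxicity, read by sulforhodamine B assay, with a stated time of 48 h (a lower number here means a stronger inhibitor, a higher number a weaker inhibitor), compound 1 gives only a limit, > 200000 nM. Compound 2 `CC(=O)OC[C@H]1O[C@@H](n2cc(Cn3cc(C(C)=O)c4ccccc43)nn2)[C@H](OC(C)=O)[C@@H](OC(C)=O)[C@@H]1OC(C)=O` bears an acetyl group instead. Compound 2 likewise returns a limit in this assay, > 200000 nM. Compound 3 `CC(=O)OC[C@H]1O[C@@H](n2cc(Cn3cc(/C=C/C(=O)c4cccnc4)c4ccccc43)nn2)[C@H](OC(C)=O)[C@@H](OC(C)=O)[C@@H]1OC(C)=O` extends the acetyl to a 2-((pyridin-3-yl)carbonyl)ethenyl group. Compound 3 also stops at a limit in this assay, > 200000 nM. The step that the two limits leave unreadable from compound 2 to compound 3 is thus unreadable. Where compound 1 stands: only a limit is known for it, and the same holds for the two other measured values, since (the limit of > 200000 nM in this assay, at which 3 of the 3 values shown sit). Compound 4 `COc1ccc2c(c1)c(/C=C1/C(=O)Nc3ccc(F)cc31)cn2Cc1cn([C@@H]2O[C@H](COC(C)=O)[C@@H](OC(C)=O)[C@H](OC(C)=O)[C@H]2OC(C)=O)nn1` is the next in line; it differs from compound 1 by a group of 12 heavy atoms (9 carbon, 1 nitrogen, 1 oxygen, 1 fluorine; one five-membered non-aromatic ring with 1 hetero atom, one six-membered aromatic ring of carbon only) in place of a group of 2 heavy atoms (1 carbon, 1 oxygen; no ring), on an aromatic carbon. No measured step bears directly on this change; the one step shown, from an acetyl to a larger ketone-bearing group, gave no readable size, so nothing points to a gain in potency. The step from compound 1 to compound 4 is expected to stay within the scatter, an at least 1.3-fold lower number from compound 1 to compound 4 (0.12 log units; that floor lies within the scatter). Compound 4 is expected to give about 150000 nM in this assay. The estimated range for compound 4 runs from 40000 nM to 400000 nM, with a fair chance that again only a limit is reported.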

Compound 4, half-maximal inhibitory concentration: > 200000 nM
Compound 4 ended at the assay's limit; the forecaster's own chance of this, stated with the estimate: 60%; at least 1.3-fold (0.12 log units) between middle value and limit.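

In this assay compound 4 gives only a limit, > 200000 nM. Going by these compounds alone, the change from compound 1 to compound 4 therefore cannot be read, and no new step results. The compounds shown leave open whether any of these groups on the shared core shifts the number in this assay, because every result stops at one value: the limit of > 200000 nM in this assay, at which 4 of the 4 values shown sit.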